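This account rests on a few compounds, and the source may have more. Where it says the series, first, only, none or still open, it means among the compounds named here.

Compound 1 `Cc1c(N)n[nH]c1-c1ccc(Cl)c(Cl)c1` returns only a limit in an assay on Sf9 cells for inhibition of mitogen-activated protein kinase kinase kinase 14 (Homo sapiens), read by ADP-Glo, with a stated time of 60 min (a lower number here means a stronger inhibitor, a higher number a weaker inhibitor), > 100000 nM. Compound 3 `CC(=O)n1nc(C)c(-c2ccc(Cl)cc2)c1N` likewise returns a limit in this assay, > 100000 nM. Among the compounds with values here, compound 2 `Cc1nn(C(=O)C2CCCC2)c(N)c1-c1ccc(Cl)c(Cl)c1` is the sole member with a number, 41000 nM in this assay. The other two values sit at the limit of > 100000 nM in this assay, at which 2 of the 3 values shown sit, so compound 2 stands alone as the one measurable point. Compound 4 `Cc1nn(C(=O)OC(C)(C)C)c(N)c1-c1ccc(Cl)c(Cl)c1` differs from compound 2 by tert-butoxy in place of cyclopentyl on a carbonyl carbon, cyclopentylcarbonyl becoming tert-butoxycarbonyl. Within the data shown here, no measured pair isolates a single change, so no step size is known for this exchange. Given compound 2 at 41000 nM, no step beyond the scatter is expected, a 1.2-fold higher number from compound 2 to compound 4 (0.09 log units; within the scatter). Compound 4 is expected near 50000 nM in this assay, within 15000 nM to 150000 nM, with a fair chance that only a limit is returned.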

Compound 4, half-maximal inhibitory concentration: > 100000 nM
Compound 4: a limit, no number; the forecaster's own chance of this, stated with the estimate: 40%; middle value at least 2.0-fold (0.30 log units) from the limit.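

Within the data shown here, replacing cyclopentyl with tert-butoxy on the carbonyl carbon gives the first readable step, an at least 2.4-fold higher number from compound 2 to compound 4 (0.38 log units; beyond the scatter) in this assay. Going by these compounds, compound 4 returns only a limit, > 100000 nM, so the full size of this step stays unknown. The one measurable value in the series is not retained once cyclopentylcarbonyl becomes tert-butoxycarbonyl, and compound 4 joins the compounds at the limit: the limit of > 100000 nM in this assay, at which 3 of the 4 values shown sit.

This single pair cannot separate loss of the ring from entry of the oxygen. A tert-butyl group or a cyclohexyl group on the same carbonyl carbon would help to tell these apart.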